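This account rests on a few compounds, and the source may have more. Where it says the series, first, only, none or still open, it means among the compounds named here.

Measured compounds in a toxicity assay on GES1 cells (Homo sapiens) for inhibition, read by MTT assay, with a stated time of 72 h; a lower number here means a stronger inhibitor, a higher number a weaker inhibitor:
Compound 1 `Cc1cc(N2CC[C@@H](C)[C@@H](N(C)c3ncnc4[nH]ccc34)C2)n2nc(SCc3ccc(Cl)cc3)nc2n1` gives > 100000 nM, a limit of the assay rather than a number.
Compound 2 `Cc1cc(N2CC[C@@H](C)[C@@H](N(C)c3ncnc4[nH]ccc34)C2)n2ncnc2n1` gives 57900 nM.
Compound 3 `COc1ccc(CSc2nc3nc(C)cc(N4CC[C@@H](C)[C@@H](N(C)c5ncnc6[nH]ccc56)C4)n3n2)cc1` gives > 100000 nM, again a limit of the assay.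

Among the compounds with values here, compound 2 therefore holds the only real number among the three; the other two sit at the limit of > 100000 nM in this assay, at which 2 of the 3 values shown sit. Compound 4 `Cc1cc(N2CC[C@@H](C)[C@@H](N(C)c3ncnc4[nH]ccc34)C2)n2nc(SCc3ccc(Br)cc3)nc2n1` differs from compound 2 by (4-bromobenzyl)sulfanyl in place of hydrogen on an aromatic carbon. Within the data shown here, two measured steps bear on this change: an at least 1.7-fold higher number from compound 2 to compound 3 (0.23 log units; that floor lies within the scatter) and, read backwards, an at least 1.7-fold lower number from compound 1 to compound 2 (0.23 log units; that floor lies within the scatter). Both show that adding a benzylsulfanyl group of this kind pushes the value up to the limit, though the size of each step cannot be read. Compound 4 is expected to behave alike, with an estimated step of a 1.7-fold higher number from compound 2 to compound 4 (0.24 log units; within the scatter). Compound 4 is thus estimated at 100000 nM, ranging from 50000 nM to 200000 nM, most likely reported only as a limit.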

Compound 4, half-maximal inhibitory concentration: 55600 nM
For compound 4 the middle estimate is 1.8-fold (0.25 log units) above the measured one; low and high end bracket the measured number.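

In this assay, placing (4-bromobenzyl)sulfanyl on this aromatic carbon leaves the value within the scatter of the unsubstituted compound: a 1.0-fold lower number from compound 2 to compound 4 (0.02 log units; within the scatter). A benzylsulfanyl group here therefore need not carry the value to the limit. Changing the substituent on the benzyl ring gives an at least 1.7-fold lower number from compound 3 to compound 4 (0.25 log units; that floor lies within the scatter) and an at least 1.7-fold lower number from compound 1 to compound 4 (0.25 log units; that floor lies within the scatter), but both are only floors: the limit of > 100000 nM in this assay, at which 2 of the 4 values shown sit.

The step between compound 1 and compound 3 cannot be read, as both values are limits. On these data alone, whether an amine or a carboxylic acid on this carbon would shift the value remains open.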